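Biaryl series: ester and sulfonamide variants, weak inhibition

The source may report more compounds than this note shows. Statements on the series, on what has been measured and on what is new or still open speak of the compounds shown alone.

Measured so far:
Compound 1 `CCOC(=O)c1ccnc(-c2ccc(OCC)cc2)c1` gives 80000 nM in an assay on COS-7 cells for inhibition of patatin-like phospholipase domain-containing protein 2 (Mus musculus); a higher number here means a weaker inhibitor, a lower number a stronger inhibitor.
Compound 2 `CCOC(=O)c1cccc(-c2ccc(OC)cc2)c1` gives 80000 nM in this assay.
Compound 3 `CCOc1ccc(-c2cccc(S(=O)(=O)N(C)C)c2)cc1` gives 110000 nM in this assay.

All three values lie within the usual scatter of each other, so compound 3 stands neither apart from compound 1 nor from compound 2 on these numbers. Compound 4 `CCOc1ccc(-c2cccc(C(=O)OCCOC)c2)cc1` has not been measured. It differs from compound 3 by (2-methoxyethoxy)carbonyl in place of dimethylsulfamoyl on an aromatic carbon. For the measured compounds named here, no step between measured compounds carries this change. Compound 2 carries an ester on the same kind of ring and gives 80000 nM, which is close to the value of compound 3, so no step beyond the scatter is expected. The step to compound 4 is expected to be a 1.2-fold lower number from compound 3 to compound 4 (0.09 log units; within the scatter). Compound 4 is estimated at 90000 nM, with a range of 40000 nM to 200000 nM.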

Compound 4, half-maximal inhibitory concentration: 70000 nM
Compound 4: the middle estimate sits 1.3-fold (0.11 log units) above what was measured; measured number inside the range.
By their numbers in this assay, from the lowest: compounds 4, 1, 2 and 3 (each within the scatter of the next).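

In this assay the exchange of dimethylsulfamoyl for (2-methoxyethoxy)carbonyl on this aromatic carbon gives a 1.6-fold lower number from compound 3 to compound 4 (0.20 log units; within the scatter) and so leaves the two groups unseparated. For the compounds shown here, this is the first direct step at this position, and it shows that a sulfonamide and an ester with a longer chain cannot be told apart here. Nothing on hand explains why these two groups read alike.

Still open, from the compounds shown here alone, is whether a carboxylic acid or an amine on this aromatic carbon would move the number beyond the scatter. Also open, going by these compounds, is whether any change at this position can do so.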